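A few compounds are considered here, and "the series" means these few. Any claim that something is new, unique, unknown or untested is made for them only; others in the source may bear on it.

Three compounds built on one shared core have been run in an ADME assay on cells (Hepatocyte, Rattus norvegicus) for metabolic stability; on this read-out higher numbers stand for fast clearance and lower numbers for slow clearance. Compound 1 `CC(C)n1cc(-c2ccnc3[nH]c(C4CCNCC4)cc23)ccc1=O` gives only a limit there, < 1 uL/min (the limit of < 1 uL/min in this assay, at which 1 of the 3 values shown sits). Compound 2 `CNC(=O)CN1CCC(c2cc3c(-c4ccc(=O)n(C(C)C)c4)ccnc3[nH]2)CC1` gives 8.9 uL/min, and compound 3 `CC(C)n1cc(-c2ccnc3[nH]c(C4CCN(CC(=O)N5CCCC5)CC4)cc23)ccc1=O` gives 5.4 uL/min; of the two proper numbers, compound 3 holds the lower, with compound 2 nearest and within the scatter. The measured steps read an at least 8.9-fold higher number from compound 1 to compound 2 (0.94 log units; beyond the scatter), an at least 5.4-fold higher number from compound 1 to compound 3 (0.73 log units; beyond the scatter) and a 1.6-fold lower number from compound 2 to compound 3 (0.22 log units; within the scatter). Compound 4 `CC(C)n1cc(-c2ccnc3[nH]c(C4CCN(Cc5cccs5)CC4)cc23)ccc1=O` differs from compound 3 in one place: thiophen-2-yl in place of (pyrrolidin-1-yl)carbonyl on a saturated chain carbon bound to an amine nitrogen in a ring. Going by the values given here, only the step from compound 2 to compound 3 touches this part of the molecule, and it stayed within the scatter, while the two larger steps concern the substituent on the amine nitrogen in a ring, which compound 4 also carries. The change is therefore expected to bring a 1.7-fold higher number from compound 3 to compound 4 (0.22 log units; within the scatter), no clearer than the scatter. Compound 4 is estimated to give 9 uL/min, between 3 uL/min and 30 uL/min.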

Compound 4, intrinsic clearance in a liver preparation (reported as CLH), per the amount of preparation that the assay uses in the Hepatocyte assay: 43 uL/min
Compound 4: the middle estimate sits 4.8-fold (0.68 log units) below what was measured; the measured number lies above the stated range.
By their numbers in the Hepatocyte assay, from the lowest: compounds 3 and 2 (each within the scatter of the next); then compound 4. At a limit, below all of these: compound 1.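

In the Hepatocyte assay, this position proves sensitive to what the saturated chain carbon carries, unlike the exchange on the carbonyl carbon: thiophen-2-yl gives an 8.0-fold higher number from compound 3 to compound 4 (0.90 log units; beyond the scatter) and a 4.8-fold higher number from compound 2 to compound 4 (0.68 log units; beyond the scatter). Against hydrogen on the amine nitrogen, (thiophen-2-yl)methyl gives an at least 43-fold higher number from compound 1 to compound 4 (1.63 log units; beyond the scatter), a step that starts from a limit. In a physicochemical assay for acid dissociation, the change also shifts the read-out, with compound 3 at 7.8 and compound 4 at 6.5, a number 1.30 log units lower from compound 3 to compound 4 (beyond the scatter).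

One pair cannot tell whether these two shifts are connected. Going by these compounds, it also remains open whether the rise in clearance follows the thiophen-2-yl ring or the loss of the carbonyl, and whether a phenyl ring or an ethyl group would behave alike.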